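This account rests on a few compounds, and the source may have more. Where it says the series, first, only, none or still open, it means among the compounds named here.

Measured so far:
compound 1 `Nc1ccc(Nc2c(C(=O)NCc3ccc(F)cc3)nc(Br)c3cccnc23)cc1`: in a functional assay on LNCaP cells (Homo sapiens) for cytotoxicity, read by MTT assay, with a stated time of 72 h (a lower number here means a stronger inhibitor, a higher number a weaker inhibitor), compound 1 gives 7000 nM.
compound 2 `NCCCNc1c(C(=O)NCc2ccc(F)cc2)ncc2cccnc12`: compound 2 gives only a limit, > 10000 nM.
compound 3 `CC(C)(C)OC(=O)N1CCN(c2c(C(=O)NCc3ccc(F)cc3)nc(Br)c3cccnc23)CC1`: compound 3 likewise gives only a limit, > 10000 nM.

Among the compounds with values here, compound 1 is thus the one member of the series with a measured number; the other two sit at the limit of > 10000 nM in this assay, at which 2 of the 3 values shown sit, so no step between measured compounds can be sized, and there is nothing to anchor a trend on.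

Compound 4 `Nc1cccc(Nc2c(C(=O)NCc3ccc(F)cc3)nc(Br)c3cccnc23)c1` differs from compound 1 in one place: 3-aminophenyl in place of 4-aminophenyl on a nitrogen on an aromatic ring. The same atoms are joined differently; nothing is added or removed. Within the data shown here, with no measured step to draw on, the change is expected to stay within the scatter, at most a slight weakening; the step is estimated as a 1.1-fold higher number from compound 1 to compound 4 (0.06 log units; within the scatter). Compound 4 is therefore expected at about 8000 nM, with a range of 3000 nM to 20000 nM.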

Compound 4, half-maximal inhibitory concentration: 8000 nM
For compound 4 middle estimate and measured number coincide at the digits printed, within the range that was stated.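

In this assay the series now has its first sized step, a 1.1-fold higher number from compound 1 to compound 4 (0.06 log units; within the scatter). On a nitrogen on an aromatic ring, 3-aminophenyl and 4-aminophenyl therefore cannot be told apart in this assay, so moving the amine around this phenyl ring does not by itself change the reading.

As far as these compounds go, whether a carboxylic acid or a methoxy group in place of that amine would give a step beyond the scatter stays open. Compound 2 and compound 3 still give only a limit: the limit of > 10000 nM in this assay, at which 2 of the 4 values shown sit.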